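The source may report more compounds than this note shows. Statements on the series, on what has been measured and on what is new or still open speak of the compounds shown alone.

Measured so far in a functional assay on cells (Lymphocyte, Homo sapiens), read by a luciferase reporter and ATP content, with a stated time of 48 h, tested at 20 uM; a higher number here means a weaker effect of the compound at the concentration tested, a lower number a stronger effect: compound 1 `CCCCCCCCCCCCCCc1nc(N2CCC2)nc(OC2CCC2)c1O` gives 94%; compound 2 `Cc1nc(OC2CCC2)nc(N2CCC2)c1O` gives 96%; compound 3 `CCCCCCCCCCCCCCc1nc(OC2CCC2)nc(OC2CCC2)c1O` gives 94%. All three values lie within the scatter of one another.

One change has already been measured: from compound 3 to compound 1, (azetidin-1-yl in place of cyclobutyloxy on an aromatic carbon), and it gave no change at the digits printed from compound 3 to compound 1 (within the scatter). The same kind of change leads from compound 2 to compound 4 `Cc1nc(N2CCC2)nc(N2CCC2)c1O`: azetidin-1-yl in place of cyclobutyloxy on an aromatic carbon. The surroundings differ, though. In compound 3 the carbon is meta to a cyclobutyloxy group and meta to a large group; in compound 2 it is meta to a methyl group and meta to an azetidin-1-yl group. How the cores of compound 2 and compound 3 differ is not broken down here.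

The step from compound 2 to compound 4 is expected to be a number 1 percentage points lower from compound 2 to compound 4 (within the scatter). This expectation rests on the earlier step, which gave no change at the digits printed from compound 3 to compound 1 (within the scatter). Compound 4 is therefore estimated at 95%, with a range from 87% to 102%.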

Compound 4, a percentage reported as activity, at one concentration (the size of the read-out at that concentration, not a potency): 85%
Compound 4: middle estimate off by 10 percentage points, on the high side; the measured number lies below the stated range.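

Azetidin-1-yl in place of cyclobutyloxy gave a number 11 percentage points lower from compound 2 to compound 4 (beyond the scatter) in this assay, and set beside the earlier step, this does not establish a difference between the two cores: the same change on two cores in this assay, no change at the digits printed (within the scatter) from compound 3 to compound 1 and a number 11 percentage points lower (beyond the scatter) from compound 2 to compound 4, 11 percentage points apart, within the scatter of two such steps. For the compounds shown here, the change thus carries over without a demonstrated effect of the core, although only the step on the core of compound 2 stands beyond the scatter. Going by these compounds alone, this does not show that the step has the same size on both cores, as each core gives only a single step.

The compounds shown leave open how a dimethylamino group would compare with azetidin-1-yl at this place. They also leave open whether the step would hold on a core carrying a hexyl chain in place of the methyl group.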